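Swapping a long acid side chain for a direct carboxy group

The compounds below may be only part of what the source reports. "The series", "measured", "known", "first", "only" and "open" are said of these compounds alone.

Measured so far:
compound 1 `O=C(O)COc1ccc([C@H]2CC[C@]3(CC2)OOC2(O3)C3CC4CC2CC(C3)C4=O)cc1` gives 1.9
compound 2 `O=C(O)CNC(=O)COc1ccc([C@H]2CC[C@]3(CC2)OOC2(O3)C3CC4CC(C3)CC2C4)cc1` gives 3
compound 3 `O=C(O)COc1ccc([C@H]2CC[C@]3(CC2)OOC2(O3)C3CC4CC2CC(C3)C4(F)F)cc1` gives 2.9

These three compounds share a core and were measured in a physicochemical assay for lipophilicity, read by HPLC, at pH 7.4; a lower number here means a more polar compound, a higher number a more lipophilic compound. Compound 2 sits at the top of the three numbers with 3. Compound 3, at 2.9, lies within the usual scatter of compound 2, so the two cannot be told apart. Compound 1, at 1.9, lies well beyond the scatter below compound 2.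

Compound 4 `O=C(O)c1ccc([C@H]2CC[C@]3(CC2)OOC2(O3)C3CC4CC(C3)CC2C4)cc1` has not yet been measured. It differs from compound 2 in one place: carboxy in place of ((carboxymethyl)carbamoyl)methoxy on an aromatic carbon. Going by the values given here, no measured pair shows exactly this kind of change, so the expectation rests on the values of compounds 2 and 3 alone. A shorter, less atom-rich acid attached straight to the aromatic ring is expected to give a number close to that of compound 2, with at most a modest rise, so the estimated step of a number 0.20 log units higher from compound 2 to compound 4 (within the scatter) is expected to be small. Compound 4 is therefore estimated at 3.2, with a likely range from 2.6 to 3.8.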

Compound 4, distribution coefficient: 3
Beside the measured number, compound 4's estimate is 0.20 log units above it, within the range that was stated.
By their numbers in this assay, from the lowest: compound 1; then compounds 3, 2 and 4 (each within the scatter of the next).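

Going by these compounds alone, this is the first step that changes only one place, and it falls on an aromatic carbon para to a large group. In this assay, carboxy in place of ((carboxymethyl)carbamoyl)methoxy gives no change at the digits printed from compound 2 to compound 4 (within the scatter), even though a group of 9 heavy atoms gives way to one of 3 heavy atoms. At this position, then, the size of the acid-bearing group can change this much with no readable shift in the number, though no measurement here explains why.

From the compounds shown here alone, it remains open whether a neutral or basic group at this position, such as an ester or an amine, would also leave the number unmoved. The same question stands for a carboxylic acid on a longer chain, and for this swap made on the core of compound 1 or compound 3.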